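The source may report more compounds than this note shows. Statements on the series, on what has been measured and on what is new or still open speak of the compounds shown alone.

Series notes. Compound 2 `CC1=C(C(=O)OCC(F)(F)F)C(c2ccsc2)NC(=O)N1` serves as the reference point; in an assay on cells for displacement of a labelled ligand from adenosine receptor A1 (Homo sapiens), read by radioligand binding, with a stated time of 60 min, tested at 1 uM (a lower number here means less inhibition, a higher number more inhibition at the concentration tested (going by the name of the read-out)), compound 2 gives 2%. Compound 1 `CC1=C(C(=O)OC(C(F)(F)F)C(F)(F)F)C(c2ccsc2)NC(=O)N1` differs from compound 2 only by trifluoromethyl in place of hydrogen on a saturated chain carbon bound to an oxygen next to a carbonyl group and a saturated chain carbon. In this assay compound 1 gives 17%, so the change amounts to a number 15 percentage points higher from compound 2 to compound 1 (beyond the scatter). Compound 3 `CC1=C(C(=O)OCC(F)(F)F)C(c2ccco2)NC(=O)N1` carries the second core of the set; against compound 2 the counted difference is furan-2-yl in place of thiophen-3-yl on a saturated ring carbon. In this assay compound 3 gives 10%, which corresponds to a number 8 percentage points higher from compound 2 to compound 3 (within the scatter); compound 3 and compound 1 likewise sit within the scatter of each other, so no order between them can be stated.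

Compound 4 `CC1=C(C(=O)OC(C(F)(F)F)C(F)(F)F)C(c2ccco2)NC(=O)N1` has not yet been run in this assay. It differs from compound 3 by trifluoromethyl in place of hydrogen on a saturated chain carbon bound to an oxygen next to a carbonyl group and a saturated chain carbon, the same change that separates compound 1 from compound 2, now carried out on the other core; the place is described in identical words in both pairs. Because the earlier instance produced a number 15 percentage points higher from compound 2 to compound 1 (beyond the scatter), a step of a number 15 percentage points higher from compound 3 to compound 4 (beyond the scatter) is expected here, resting on that single prior pair alone. In this assay compound 4 is estimated at 25%, with a likely range from 10% to 40%.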

Compound 4, a percentage reported as inhibition, at one concentration (the size of the read-out at that concentration, not a potency): 6%
The estimate for compound 4 lay 19 percentage points above the measured number; the whole stated range lies above it.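

In this assay, trifluoromethyl in place of hydrogen gives a number 4 percentage points lower from compound 3 to compound 4 (within the scatter), so the rise seen on the core of compound 1 does not carry over to the core of compound 3: the same change on two cores in this assay, a number 15 percentage points higher (beyond the scatter) from compound 2 to compound 1 and a number 4 percentage points lower (within the scatter) from compound 3 to compound 4, 19 percentage points apart, beyond the scatter of two such steps The same four compounds, read along the other change, furan-2-yl in place of thiophen-3-yl, give a number 11 percentage points lower from compound 1 to compound 4 (beyond the scatter), so that change also depends on what the ester chain carries: the same change on two cores in this assay, a number 8 percentage points higher (within the scatter) from compound 2 to compound 3 and a number 11 percentage points lower (beyond the scatter) from compound 1 to compound 4, 19 percentage points apart, beyond the scatter of two such steps This shows that neither change can be treated as a fixed increment across these four compounds, but it does not give a reason for the mismatch or a rule for any further core, since each step rests on a single pair read at one concentration, as inhibition rather than potency.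

What the compounds shown leave open is how the series behaves when the ester chain ends in something other than hydrogen or trifluoromethyl, such as an amine, a carboxylic acid or a longer chain. Whether the same mismatch between cores would appear with those groups remains undetermined.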